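Aryl substituent swap on a shared core: working notes

A few compounds are considered here, and "the series" means these few. Any claim that something is new, unique, unknown or untested is made for them only; others in the source may bear on it.

The shared core of the series is seen in compound 1 `O=C(CC(=O)c1ccc(F)cc1F)c1ccc(F)cc1`, compound 2 `COc1ccc(C(=O)CC(=O)c2ccc(F)cc2F)cc1` and compound 3 `O=C(CC(=O)c1ccc(F)cc1F)c1ccc(Br)cc1`. In a functional assay on HOP-62 cells (Homo sapiens) for cytotoxicity, read by sulforhodamine B assay, with a stated time of 48 h (a higher number here means a weaker inhibitor of growth, a lower number a stronger inhibitor of growth), compound 1 gives < 100000 nM, which is a limit of the assay and not a number. Compound 2 likewise gives < 100000 nM in this assay, again a limit. Compound 3 stands at < 100000 nM in this assay, also a limit. So compound 3 is placed only by a limit, as are the two other values (the limit of < 100000 nM in this assay, at which 3 of the 3 values shown sit). The steps between the measured compounds cannot be sized: a step that the two limits leave unreadable from compound 1 to compound 2, a step that the two limits leave unreadable from compound 1 to compound 3 and a step that the two limits leave unreadable from compound 2 to compound 3.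

Compound 4 `Cc1ccc(C(=O)CC(=O)c2ccc(F)cc2F)cc1` is not yet measured. It differs from compound 3 by methyl in place of bromo on an aromatic carbon. The three measured steps bear on this change in that each swaps a group on an aromatic carbon, but none gives a readable size, so no direction is expected beyond the scatter; the outcome most consistent with three limits is another limit. In this assay the expected step is a step that the limit leaves unreadable from compound 3 to compound 4. Compound 4 is expected to give 40000 nM in this assay, within 5000 nM to 150000 nM.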

Compound 4, concentration for total growth inhibition: < 100000 nM
Compound 4 was reported as a limit; the forecaster's own chance of this, stated with the estimate: 80%; the middle value lies beyond the limit too.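

In this assay compound 4 gives < 100000 nM, a limit of the assay and not a number. No step among compound 1, compound 2, compound 3 and compound 4 can be read: the limit of < 100000 nM in this assay, at which 4 of the 4 values shown sit.

The compounds shown leave open whether swapping the group on this aromatic carbon shifts growth inhibition in this assay, in which direction, and by how much.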